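This account rests on a few compounds, and the source may have more. Where it says the series, first, only, none or still open, it means among the compounds named here.

The shared core appears in compound 1 `C=CC1=C(C(=O)NCc2ccc(Cl)cc2)C(c2ccc(F)cc2)OC1`, compound 2 `C=CC1=C(C(=O)Nc2ccccc2)C(c2ccc(Cl)c(Cl)c2)OC1` and compound 3 `C=CC1=C(C(=O)Nc2ccc(OCC)cc2)C(c2ccc(OC)cc2)OC1`, each tested in a functional assay on SW480 cells (Homo sapiens) for cytotoxicity, read by MTT assay, with a stated time of 24 h; a higher number here means a weaker inhibitor, a lower number a stronger inhibitor. In this assay compound 1 returns only a limit, > 100000 nM. Compound 2 likewise returns only a limit, > 100000 nM. Compound 3 is also known only as a limit, > 100000 nM. Within the data shown here, compound 3 therefore stands where every measured value stands, at the limit of > 100000 nM in this assay, at which 3 of the 3 values shown sit, and no step between measured compounds can be drawn. Compound 4 `C=CC1=C(C(=O)NCc2ccc(Cl)cc2)C(c2ccc(OC)cc2)OC1` differs from compound 3 by 4-chlorobenzyl in place of 4-ethoxyphenyl on an amide-type nitrogen. Both compound 1 and compound 3 sit at the limit of > 100000 nM in this assay, at which 3 of the 3 values shown sit. The expected step is accordingly none beyond the scatter, a step that the limit leaves unreadable from compound 3 to compound 4. Compound 4 is expected at 150000 nM, within 60000 nM to 400000 nM, most probably again reported only as a limit.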

Compound 4, half-maximal inhibitory concentration: > 100000 nM
Compound 4 gave a limit, no number; the forecaster's own chance of this, stated with the estimate: 85%; the middle value lies beyond the limit too.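

Compound 4 returns only a limit, as compound 1 and compound 3 do, so no step to compound 4 can be read from either of them: the limit of > 100000 nM in this assay, at which 4 of the 4 values shown sit.

The compounds shown leave open whether any change to the shared core gives a measurable value in this assay.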